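Swapping Fluoro for Bromo on the Aryl Urea

This account rests on a few compounds, and the source may have more. Where it says the series, first, only, none or still open, it means among the compounds named here.

Of the compounds shown here, three sharing one core have been tested: compound 1 `COc1ccc(NC(=O)Nn2c(-c3ccccc3)nc3ccccc3c2=O)cc1`, compound 2 `Cc1cccc(NC(=O)Nn2c(-c3ccccc3)nc3ccccc3c2=O)c1` and compound 3 `O=C(Nc1ccc(F)cc1)Nn1c(-c2ccccc2)nc2ccccc2c1=O`. In a functional assay on the whole organism (strain albino) with Mus musculus as the target, at a dose of 100 mg/kg by the intraperitoneal route (a higher number here means more inhibition at the dose given (going by the name of the read-out), a lower number less inhibition), compound 1 gives 52%, compound 2 gives 59% and compound 3 gives 54%. Compound 3 holds the second highest of the three numbers: a number 2 percentage points higher from compound 1 to compound 3 (within the scatter) and a number 5 percentage points lower from compound 2 to compound 3 (within the scatter), so all three lie within the usual scatter of one another. Compound 4 `O=C(Nc1ccc(Br)cc1)Nn1c(-c2ccccc2)nc2ccccc2c1=O` has not been measured; it differs from compound 3 by bromo in place of fluoro on an aromatic carbon. The steps bearing on exchanging the group on the aromatic carbon, a number 2 percentage points higher from compound 1 to compound 3 (within the scatter) and a number 5 percentage points lower from compound 2 to compound 3 (within the scatter), stayed within the scatter, as did a number 7 percentage points higher from compound 1 to compound 2 (within the scatter). Compound 4 is therefore expected to show a number 1 percentage points higher from compound 3 to compound 4 (within the scatter), none beyond the scatter. Compound 4 is estimated at 55%, between 42% and 68%.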

Compound 4, a percentage reported as inhibition, in the whole organism at one dose (the size of the read-out at that dose, not a potency): 58%
Beside the measured number, compound 4's estimate is 3 percentage points below it; the measured number falls inside the stated range.
By their numbers in this assay, from the lowest: compounds 1, 3, 4 and 2 (each within the scatter of the next).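

In this assay, the exchange gives a number 4 percentage points higher from compound 3 to compound 4 (within the scatter), so a much larger halogen atom on this aromatic carbon, para to a large group, produces no step beyond the scatter. The other new steps, a number 1 percentage points lower from compound 2 to compound 4 (within the scatter) and a number 6 percentage points higher from compound 1 to compound 4 (within the scatter), also stay within the scatter, so methoxy, fluoro and bromo at this position cannot be told apart in this read-out. Nothing available explains this result. Open, as far as these compounds go, is whether an amine or a carboxylic acid on this carbon would give a step beyond the scatter.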